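The compounds below may be only part of what the source reports. "The series", "measured", "known", "first", "only" and "open" are said of these compounds alone.

Among the compounds with values here, compound 1, `COC[C@H](C)[C@H](C)C(c1ccc(O)c(OC)c1)c1ccc(O)c(OC)c1`, is the weakest of the three compounds measured so far: in a functional assay on HL-60 cells (Homo sapiens) for cytotoxicity, read by WST assay, with a stated time of 48 h (a higher number here means a weaker inhibitor, a lower number a stronger inhibitor), compound 1 gives 82000 nM. Compound 2, `COc1cc(C(c2ccc(O)c(OC)c2)[C@H](C)C(C)C)ccc1O`, gives 17000 nM in this assay, and compound 3, `COc1cc(C(c2ccc(O)c(OC)c2)[C@H](CC(C)C)C(C)C)ccc1O`, gives 9600 nM. Those two sit close together, the step of a 1.8-fold lower number from compound 2 to compound 3 (0.25 log units; within the scatter) lying within the usual scatter, while the steps of a 4.8-fold lower number from compound 1 to compound 2 (0.68 log units; beyond the scatter) and an 8.5-fold lower number from compound 1 to compound 3 (0.93 log units; beyond the scatter) are both beyond it, so compound 1 stands clearly apart at the high end. Within the data shown here, compound 4, `COC[C@@H](C)[C@H](C)C(c1ccc(O)c(OC)c1)c1ccc(O)c(OC)c1`, is not yet measured. the two compounds have the same atoms and bonds and differ only in configuration as drawn: 1 of 2 stereo elements differ; a stereocentre at a saturated chain carbon is drawn R in compound 1 and S in compound 4 Every measured step replaces one group with another on a saturated chain carbon; none compares two arrangements of the same atoms, so no measured step speaks to a change in configuration alone. Without such a comparison the expected step of a 1.0-fold lower number from compound 1 to compound 4 (0.01 log units; within the scatter) is none beyond the scatter, although a change of configuration can move a number either way. Compound 4 is therefore estimated at 80000 nM in this assay, with a range from 25000 nM to 250000 nM.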

Compound 4, half-maximal inhibitory concentration: 73000 nM
For compound 4 the middle estimate is 1.1-fold (0.04 log units) above the measured one; measured number inside the range.
By their numbers in this assay, from the lowest: compounds 3 and 2 (each within the scatter of the next); then compounds 4 and 1 (each within the scatter of the next).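

In this assay, within the data shown here, this pair is the first direct test of a change in configuration alone, and moving the stereocentre at the saturated chain carbon from R to S gives a 1.1-fold lower number from compound 1 to compound 4 (0.05 log units; within the scatter), so this change at this position shows no effect beyond the scatter. The reading is a clean one, with nothing else to account for the result: the fact that compounds 1 and 4 differ only in the configuration as drawn. With the S drawing, the 2-(methoxymethyl)-1-methylpropyl group still stands apart from the 1-isopropyl-3-methylbutyl and 1,2-dimethylpropyl groups, with a 7.6-fold higher number from compound 3 to compound 4 (0.88 log units; beyond the scatter) and a 4.3-fold higher number from compound 2 to compound 4 (0.63 log units; beyond the scatter).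

As far as these compounds go, the second stereo element is drawn alike in compounds 1 and 4, so the effect of changing it remains open. Also open, from the compounds shown here alone, is how a hydroxymethyl or aminomethyl group in place of the methoxymethyl part would behave in either configuration.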